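The source may report more compounds than this note shows. Statements on the series, on what has been measured and on what is new or still open speak of the compounds shown alone.

Of the compounds shown here, three have so far been measured in a functional assay on the whole organism (stomach) with Rattus norvegicus as the target; a higher number here means that more compound is needed for the effect, a lower number that less compound is needed. Compound 1 `O=C(Nc1ccc(-c2nn[nH]n2)cc1)c1cccc(-c2nn[nH]n2)c1` gives 0.6 mg/kg in this assay. Compound 2 `O=C(Nc1ccccc1)c1ccc(-c2nn[nH]n2)cc1` gives 40 mg/kg. Compound 3 `O=C(O)c1cc(NC(=O)c2ccc([N+](=O)[O-])cc2)cc(C(=O)O)c1` gives 61.1 mg/kg, the highest of the three numbers. The gap between compound 3 and compound 2 lies within the usual scatter, so nothing can be read into their order, whereas compound 1 stands far from compound 3, at a distance well beyond the scatter.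

The compound not yet measured, compound 4 `CCCc1ccc(C(=O)Nc2cc(C(=O)O)cc(C(=O)O)c2)cc1`, differs from compound 3 in one place only: propyl in place of nitro on an aromatic carbon. For the measured compounds named here, no measured pair in the set shows this same change, so there is no directly comparable step to lean on, and the measured compounds differ from one another in several places at once. The step expected from this change, a 1.5-fold lower number from compound 3 to compound 4 (0.18 log units; within the scatter), is accordingly estimated to be modest, pointing toward a somewhat lower number but not with confidence beyond the scatter. Compound 4 is therefore estimated at 40 mg/kg in this assay, with a range from 10 mg/kg to 150 mg/kg within which most repeated measurements would be expected to fall.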

Compound 4, dose for 50% inhibition: 94.2 mg/kg
Beside the measured number, compound 4's estimate is 2.4-fold (0.37 log units) below it; the measured number falls inside the stated range.
By their numbers in this assay, from the lowest: compound 1; then compounds 2, 3 and 4 (each within the scatter of the next, the first and the last beyond it).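

For the compounds shown here, compounds 3 and 4 form the first pair in this set that differs in one place only, so the change can now be read directly: propyl in place of nitro, on an aromatic carbon para to a large group, gives a 1.5-fold higher number from compound 3 to compound 4 (0.19 log units; within the scatter) in this assay. At this position, a group of nitrogen and oxygen with two hydrogen-bond acceptors and a group of carbon alone with none, each of three heavy atoms, thus give numbers that cannot be told apart, and this single pair shows no effect of the change on the dose needed. Nothing among the available data bears on why the two numbers lie so close.

From the compounds shown here alone, it remains open whether any group at this position would move the number beyond the scatter, for instance an amine, a carboxylic acid or a longer chain than propyl. Going by these compounds alone, it also remains open whether propyl in place of nitro would give a similar step on another core, as this one pair is the only example of the change.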